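The source may report more compounds than this note shows. Statements on the series, on what has been measured and on what is new or still open speak of the compounds shown alone.

In a functional assay, read by fluorescence and spectrophotometry, with a stated time of 1 h (a lower number here means that less compound is needed, a higher number that more compound is needed for the effect), compound 1 `CCCCCCCCCCCS(=O)(=O)/C=C/c1ccc(O)c(O)c1` gives 11400 nM, compound 2 `CCCCCCCCS(=O)(=O)/C=C/c1ccc(O)c(O)c1` gives 6400 nM and compound 3 `O=S(=O)(/C=C/c1ccc(O)c(O)c1)CCCC1CCCC1` gives 6300 nM. Compound 3 therefore stands within the scatter of both others. Compound 4 `O=S(=O)(/C=C/c1ccc(O)c(O)c1)CCCc1ccccc1` differs from compound 3 in one place: phenyl in place of cyclopentyl on a saturated chain carbon, three bonds along the chain from a sulfonyl sulfur. The closest evidence comes from changes to the same chain: a 1.8-fold lower number from compound 1 to compound 2 (0.25 log units; within the scatter), a 1.8-fold lower number from compound 1 to compound 3 (0.26 log units; within the scatter) and a 1.0-fold lower number from compound 2 to compound 3 (0.01 log units; within the scatter), all within the scatter. None of these steps brings in an aromatic ring, so the evidence is indirect. No step beyond the scatter is therefore expected in this assay, and the estimated step is a 1.1-fold lower number from compound 3 to compound 4 (0.02 log units; within the scatter). The estimate for compound 4 is 6000 nM, with an expected range of 2500 nM to 15000 nM.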

Compound 4, half-maximal effective concentration: 11500 nM
Estimate against measurement, compound 4: 1.9-fold (0.28 log units) below; the range from low to high includes it.
By their numbers in this assay, from the lowest: compounds 3, 2, 1 and 4 (each within the scatter of the next).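

In this assay compound 4 brings an aromatic ring to this chain position, and replacing cyclopentyl with phenyl gives a 1.8-fold higher number from compound 3 to compound 4 (0.26 log units; within the scatter) so this change of ring stays within the scatter. Phenyl in place of the open chains gives a 1.8-fold higher number from compound 2 to compound 4 (0.25 log units; within the scatter) and a 1.0-fold higher number from compound 1 to compound 4 (0.00 log units; within the scatter) and neither step can be told apart from the scatter either. No measurement here accounts for these numbers.

Going by these compounds, whether a pyridine ring at this place would give a step beyond the scatter remains open. The same question stands for a chain ending in an amine or a carboxylic acid.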